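Chloro in place of hydroxy on the aryl ketone

The source may hold more compounds than are shown below. What is called first, only, known or untested is meant among the compounds shown, and "the series" means these compounds.

In a functional assay on MDA-MB-468 cells (Homo sapiens) for cytotoxicity, read by sulforhodamine B assay, with a stated time of 24 h (on this read-out higher numbers stand for weaker inhibition of growth and lower numbers for stronger inhibition of growth), compound 2 `O=C(/C=C/c1cc2ccccc2[nH]c1=O)c1ccc(O)cc1` gives 5300 nM, while compound 1 `COc1ccc(C(=O)/C=C/c2cc3ccccc3[nH]c2=O)cc1` gives 5980 nM; the step of a 1.1-fold lower number from compound 1 to compound 2 (0.05 log units; within the scatter) lies within the scatter. Compound 3 `O=C(/C=C/c1cc2ccccc2[nH]c1=O)c1ccc(Cl)cc1` carries chloro in place of hydroxy on an aromatic carbon. Within the data shown here, the one measured step changes the same oxygen without removing it, so it bears only loosely on this exchange; no measured step follows the loss of the hydroxy itself. The expected step is therefore small, estimated as a 1.1-fold lower number from compound 2 to compound 3 (0.03 log units; within the scatter). The estimate for compound 3 is 5000 nM, with a range from 1500 nM to 16000 nM.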

Compound 3, concentration for total growth inhibition: 9880 nM
For compound 3 the middle estimate is 2.0-fold (0.30 log units) below the measured one; low and high end bracket the measured number.
By their numbers in this assay, from the lowest: compounds 2, 1 and 3 (each within the scatter of the next).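

In this assay, the exchange of hydroxy for chloro on this aromatic carbon gives a 1.9-fold higher number from compound 2 to compound 3 (0.27 log units; within the scatter), and the exchange of methoxy for chloro gives a 1.7-fold higher number from compound 1 to compound 3 (0.22 log units; within the scatter). Neither step leaves the scatter, so here the oxygen can give way to chloro, which brings no hydrogen-bond donor or acceptor, without a step beyond the scatter. Nothing available bears on the reason for these steps. The compounds shown leave open whether an amine or a carboxylic acid on this carbon would also stay within the scatter.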